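Cytotoxicity notes: one untested change on compound 1

This account rests on a few compounds, and the source may have more. Where it says the series, first, only, none or still open, it means among the compounds named here.

Measured so far:
compound 1 `COC(=O)c1ccc(NCc2cncn2Cc2cccc([N+](=O)[O-])c2)cc1-c1ccccc1`; in a toxicity assay on NIH3T3 cells (Mus musculus) for cytotoxicity, read by resazurin assay (a lower number here means that less compound is needed, a higher number that more compound is needed for the effect), compound 1 gives > 10000 nM, a limit of the assay and not a number.
compound 2 `CC(C)c1ccc(Cn2cncc2CNc2ccc(-c3nc4ccccc4s3)c(-c3ccccc3)c2)cc1`; in this assay compound 2 gives > 1000 nM, likewise a limit.

Compound 1 stands at the limit of > 10000 nM in this assay, at which 1 of the 2 values shown sits. Compound 2 stands at the limit of > 1000 nM in this assay, at which 1 of the 2 values shown sits. For the measured compounds named here, neither value is a number, so no step between measured compounds can be given.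

Compound 3 `COC(=O)c1ccc(NCc2cncn2Cc2ccc(-c3ccccc3)cc2)cc1-c1ccccc1` differs from compound 1 by 4-phenylphenyl in place of 3-nitrophenyl on a saturated chain carbon bound to an aromatic nitrogen. The step that the limit leaves unreadable from compound 1 to compound 3 is expected to stay within the scatter, since compound 1 itself shows only a limit > 10000 nM. Compound 3 is estimated at 12000 nM, between 3000 nM and 50000 nM, and most likely again reported only as a limit.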

Compound 3, half-maximal effective concentration: > 1000 nM
Compound 3 ended at the assay's limit; the forecaster's own chance of this, stated with the estimate: 70%; the middle value lies beyond the limit too.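

In this assay compound 3 gives > 1000 nM as a limit and not a number. Compound 1 gives > 10000 nM as a limit too. For the compounds shown here, no step between compound 1 and compound 3 can be read. The compounds shown leave open whether 4-phenylphenyl and 3-nitrophenyl differ at all in cytotoxicity.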